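Methyl in Place of Methoxy: Estimating One Step

The source may hold more compounds than are shown below. What is called first, only, known or untested is meant among the compounds shown, and "the series" means these compounds.

In a functional assay on L1210 cells (Mus musculus) for inhibition, read by cell counting, with a stated time of 48 h (a higher number here means a weaker inhibitor, a lower number a stronger inhibitor), compound 1 `CCN(CC)CN1C(=O)/C(=N/NC(=S)Nc2ccccc2)c2cc(Cl)ccc21` gives 49000 nM, compound 2 `CCN(CC)CN1C(=O)/C(=N/NC(N)=S)c2cc(Cl)ccc21` gives 148000 nM, and compound 3 `CCN(CC)CN1C(=O)/C(=N/NC(=S)Nc2ccc(OC)cc2)c2cc(Cl)ccc21` gives 11000 nM. Going by the values given here, that makes compound 3 the strongest inhibitor of the three so far. The next structure, compound 4 `CCN(CC)CN1C(=O)/C(=N/NC(=S)Nc2ccc(C)cc2)c2cc(Cl)ccc21`, has methyl in place of methoxy on an aromatic carbon, para to a large group: methyl in place of methoxy on an aromatic carbon.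

The closest measured change is a 4.5-fold lower number from compound 1 to compound 3 (0.65 log units; beyond the scatter), where methoxy replaces hydrogen on that aromatic carbon. The substituent on the amide-type nitrogen also matters: removing phenyl gives a 3.0-fold higher number from compound 1 to compound 2 (0.48 log units; beyond the scatter), and installing 4-methoxyphenyl in place of hydrogen gives a 13-fold lower number from compound 2 to compound 3 (1.13 log units; beyond the scatter). Among the compounds with values here, no measured compound carries the methyl group, so its effect remains open. Methyl may recover only part of the gain seen with methoxy in a 4.5-fold lower number from compound 1 to compound 3 (0.65 log units; beyond the scatter), which points to a modest move toward a higher number in this assay. The expected step is a 2.3-fold higher number from compound 3 to compound 4 (0.36 log units; beyond the scatter). For compound 4, the estimated value is 25000 nM, with an expected range of 9000 nM to 60000 nM.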

Compound 4, half-maximal inhibitory concentration: 9500 nM
The estimate for compound 4 lay 2.6-fold (0.42 log units) above the measured number; the measured number falls inside the stated range.
By their numbers in this assay, from the lowest: compounds 4 and 3 (each within the scatter of the next); then compound 1; then compound 2.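

In this assay the exchange at this aromatic carbon makes no readable difference: a 1.2-fold lower number from compound 3 to compound 4 (0.06 log units; within the scatter) and so methyl and methoxy cannot be told apart here. Methyl alone also gives a 5.2-fold lower number from compound 1 to compound 4 (0.71 log units; beyond the scatter) showing that a move to a lower number at this position does not require the oxygen of methoxy, and a 16-fold lower number from compound 2 to compound 4 (1.19 log units; beyond the scatter) shows that 4-methylphenyl on the amide-type nitrogen, like 4-methoxyphenyl, gives a large step from hydrogen. Nothing available explains why these two groups read alike here.

Only hydrogen, methyl and methoxy appear at this position, so these compounds define no trend across substituents. Going by these compounds, whether an amine, a carboxylic acid or a longer chain such as butyl on the same aromatic carbon would match these numbers remains open.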